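Swapping a pyridyl for an ethyl amide on a sulfonamide

The source may report more compounds than this note shows. Statements on the series, on what has been measured and on what is new or still open speak of the compounds shown alone.

Measured so far:
compound 1, `COc1ccc(Cl)cc1S(=O)(=O)Nc1cncc(-c2ccccc2C)c1`: "not determined" (no result reported)
compound 2, `COc1ccc(Cl)cc1S(=O)(=O)Nc1cncc(-c2cccc(C)c2)c1`: "not determined" (no result reported)
compound 3, `COc1ccc(Cl)cc1S(=O)(=O)Nc1cncc(-c2ccncc2)c1`: > 20000 nM

Three compounds share one sulfonamide core, and only one of them carries a result. In an assay on isolated protein for inhibition of alkaline phosphatase, tissue-nonspecific isozyme (Homo sapiens) (a higher number here means a weaker inhibitor, a lower number a stronger inhibitor), compound 1 gives "not determined" (no result reported) and compound 2 gives "not determined" (no result reported). In this assay compound 3 gives no number, only a limit, > 20000 nM. Compound 3 therefore stands at the limit of > 20000 nM in this assay, at which 1 of the 3 values shown sits, and compounds 1 and 2 add nothing that could be placed beside it. Among the measured compounds shown here, no step between measured compounds exists here.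

Compound 4, `CCNC(=O)c1cncc(NS(=O)(=O)c2cc(Cl)ccc2OC)c1`, is the next one to be measured. It differs from compound 3 in one place: ethylcarbamoyl in place of pyridin-4-yl on an aromatic carbon.

Because compound 3 reaches only the limit > 20000 nM, the step that the limit leaves unreadable from compound 3 to compound 4 is expected to be small, with little room for a clear direction. Compound 4 is expected to give about 25000 nM, within a wide range from 5000 nM to 100000 nM.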

Compound 4, half-maximal inhibitory concentration: > 20000 nM
Compound 4: only a limit was reported; the forecaster's own chance of this, stated with the estimate: 60%; the middle value is on the limit's open side.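

In this assay, no step can be read from compound 3 to compound 4, since both reach only a limit and give no number: the limit of > 20000 nM in this assay, at which 2 of the 4 values shown sit.

The compounds shown leave open how strongly either compound inhibits, and whether pyridin-4-yl and ethylcarbamoyl differ at all.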